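This account rests on a few compounds, and the source may have more. Where it says the series, first, only, none or still open, it means among the compounds named here.

Compound 1 `CCN(C)CCCOc1ccc2cc(NC(=O)c3ccc(O)c(CC=C(C)C)c3)c(=O)oc2c1C`: 730 nM
Compound 2 `CC(C)=CCc1cc(C(=O)Nc2cc3ccc(OCCCNC(C)C)c(C)c3oc2=O)ccc1O`: 750 nM

In a functional assay on SK-BR-3 cells (Homo sapiens) for antiproliferative activity (on this read-out lower numbers stand for stronger inhibition and higher numbers for weaker inhibition), compound 2 gives 750 nM, level with compound 1 within the scatter. Compound 3 `CC(C)=CCc1cc(C(=O)Nc2cc3ccc(OCCCN(C)C(C)C)c(C)c3oc2=O)ccc1O` differs from compound 2 by methyl in place of hydrogen on an amine nitrogen, with methyl in place of hydrogen on an amine nitrogen. For the measured compounds named here, only one measured step bears on this change. It also alters the groups on that nitrogen: a 1.0-fold higher number from compound 1 to compound 2 (0.01 log units; within the scatter). With that single step as a guide, no shift beyond the scatter is expected in this assay. The expected step is a 1.0-fold lower number from compound 2 to compound 3 (0.01 log units; within the scatter). The estimate for compound 3 is 740 nM, with an expected range of 380 nM to 1500 nM.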

Compound 3, half-maximal inhibitory concentration: 570 nM
Compound 3: middle estimate off by 1.3-fold (0.11 log units), on the high side; measured number inside the range.
By their numbers in this assay, from the lowest: compounds 3, 1 and 2 (each within the scatter of the next).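

In this assay the amine nitrogen accepts one more methyl, turning isopropylamino into isopropyl(methyl)amino, with a 1.3-fold lower number from compound 2 to compound 3 (0.12 log units; within the scatter) as the result. Methyl in place of hydrogen on the saturated chain carbon bound to that nitrogen likewise gives a 1.3-fold lower number from compound 1 to compound 3 (0.11 log units; within the scatter) and so adds no clear change. No measurement here offers an explanation for these small steps.

The compounds shown leave open how a primary amine would compare at this position. They also leave open what a longer chain between the oxygen and the nitrogen would do.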